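Ethyl in Place of Ethynyl: Predicting Compound 4

The source may hold more compounds than are shown below. What is called first, only, known or untested is meant among the compounds shown, and "the series" means these compounds.

The measured compounds in a functional assay on CCRF-CEM cells (Homo sapiens) for antiproliferative activity, read by cell counting, with a stated time of 72 h; a lower number here means a stronger inhibitor, a higher number a weaker inhibitor:
Compound 1, `C#C[C@@]1(O)[C@@H](CO)O[C@@H](n2cc(F)c3c(N)ncnc32)[C@@H]1O`, gives 160 nM.
Compound 2, `C#C[C@@]1(O)[C@@H](CO)O[C@@H](n2cc(Cl)c3c(N)ncnc32)[C@@H]1O`, gives 12 nM.
Compound 3, `C#Cc1cn([C@@H]2O[C@H](CO)[C@](O)(C#C)[C@H]2O)c2ncnc(N)c12`, gives 63000 nM.

Compound 2 stands lowest of the three numbers in this assay. Its nearest neighbour is compound 1, with a 13-fold lower number from compound 1 to compound 2 (1.12 log units; beyond the scatter); its furthest is compound 3, with a 5300-fold higher number from compound 2 to compound 3 (3.72 log units; beyond the scatter). The step of a 390-fold higher number from compound 1 to compound 3 (2.60 log units; beyond the scatter) shows the same pattern: among these three, the group on the aromatic carbon drives the numbers, with chloro best and ethynyl worst.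

Compound 4, `CC[C@@]1(O)[C@@H](CO)O[C@@H](n2cc(Cl)c3c(N)ncnc32)[C@@H]1O`, differs from compound 2 elsewhere: ethyl in place of ethynyl on a saturated ring carbon. Among the compounds with values here, none of the three measured steps touches this saturated ring carbon, so no step directly bears on it; all three concern the aromatic carbon. Within the data shown here, compound 2 is the only measured compound bearing chloro there, and the ethynyl on the saturated ring carbon is common to compounds 1, 2 and 3, so the data give no read on what ethyl in its place does. The expectation therefore rests on the absence of evidence rather than on a measured analogue, and a step beyond the scatter in this assay, in the direction of a higher number, is considered more likely than no change. Compound 4 is estimated at 400 nM, within 40 nM to 4000 nM, which would mean an expected step of a 33-fold higher number from compound 2 to compound 4 (1.52 log units; beyond the scatter).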

Compound 4, half-maximal inhibitory concentration: 2600 nM
Beside the measured number, compound 4's estimate is 6.5-fold (0.81 log units) below it; the measured number falls inside the stated range.
By their numbers in this assay, from the lowest: compound 2; then compound 1; then compound 4; then compound 3.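

In this assay, within the data shown here, with chloro held on the aromatic carbon, ethyl in place of ethynyl on the saturated ring carbon gives a 220-fold higher number from compound 2 to compound 4 (2.34 log units; beyond the scatter), so this position, which carried ethynyl in all of the earlier compounds, proves as sensitive as the aromatic carbon. The two groups are alike in the counts, with the same heavy-atom number, no ring, and no hydrogen-bond donors or acceptors, and the one counted difference is the triple bond that leaves, so a large shift here does not go with any change in the number of heavy atoms. Nothing available explains why the number rises with this exchange.

As far as these compounds go, it remains open how a methyl, a vinyl group or a longer chain such as propyl would fare on this saturated ring carbon, and so whether the triple bond itself is what matters or whether other small carbon groups would serve as well. From the compounds shown here alone, it is also open whether ethyl in place of ethynyl would produce a step of similar size with fluoro on the aromatic carbon.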